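The source may hold more compounds than are shown below. What is called first, only, known or untested is meant among the compounds shown, and "the series" means these compounds.

Measured so far:
Compound 1, `CC(=O)O[C@H](CC/C(C)=C/CCc1ccc2c(c1)C(=O)C(C)=CC2=O)[C@@](C)(O)CCC=C(C)C`: in a functional assay on A549 cells (Homo sapiens) for cytotoxicity, read by MTT assay, with a stated time of 6 days (a higher number here means a weaker inhibitor, a lower number a stronger inhibitor), compound 1 gives 33900 nM.
Compound 2, `CC(C)=CCC/C(=C/CC/C(C)=C/CC/C(C)=C/CC1=CC(=O)C(C)=CC1=O)CO`: in this assay compound 2 gives > 48800 nM.

The value for compound 2 is not a number but a limit of the assay, the point at which (the limit of > 48800 nM in this assay, at which 1 of the 2 values shown sits). From the compounds shown here alone, compound 2 therefore stands at the weak end of what this assay can report, and its exact position is unknown.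

Compound 3, `CC(=O)OC/C(=C\CC/C(C)=C/CC/C(C)=C/CC1=CC(=O)C(C)=CC1=O)CCC=C(C)C`, has not yet been tested. It differs from compound 2 in one place: acetyl in place of hydrogen on an oxygen on a saturated carbon. The hydroxymethyl of compound 2 becomes an acetoxymethyl. Among the compounds with values here, no pair of measured compounds shares this change, so no step size can be read from the data. Compound 1 also carries an acetoxy group on its chain and reaches only 33900 nM in this assay, which suggests that the acetyl brings no large gain. The step of an at least 1.2-fold lower number from compound 2 to compound 3 (0.08 log units; that floor lies within the scatter) is expected to stay within the usual scatter, with a fair chance that only a limit is reported again. Compound 3 is expected to give 40000 nM, in a likely range from 15000 nM to 110000 nM.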

Compound 3, half-maximal inhibitory concentration: 38100 nM
For compound 3 the middle estimate is 1.0-fold (0.02 log units) above the measured one, within the range that was stated.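

In this assay compound 2 gives > 48800 nM, which is a limit of the assay and not a number. With acetyl in place of hydrogen on an oxygen on a saturated carbon, turning the hydroxymethyl into an acetoxymethyl, compound 3 gives 38100 nM, so this position now has a measured number in this assay. The change gives an at least 1.2-fold lower number from compound 2 to compound 3 (0.10 log units; that floor lies within the scatter), and this floor is all that can be said of its size, because one end of the step is not a number: the limit of > 48800 nM in this assay, at which 1 of the 3 values shown sits.

From the compounds shown here alone, what stays open is how far past its limit compound 2 really lies, and therefore whether the acetyl changes the result at this position by a little, by a lot, or hardly at all. Also open, going by these compounds, is how other groups on the same oxygen or in place of it would read in this assay, for example a longer acyl chain such as butyryl, a methyl ether, a carboxylic acid or an amine.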